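A few compounds are considered here, and "the series" means these few. Any claim that something is new, unique, unknown or untested is made for them only; others in the source may bear on it.

In a functional assay on the whole organism (heart) with Rattus norvegicus as the target (a lower number here means that less compound is needed, a higher number that more compound is needed for the effect), compound 1 `CC(=O)/C(=C\c1ccccc1)Oc1ccccc1OCC(C)N(C)C` gives 0.9 mg/kg and lies within the scatter of compound 3 `CC(=O)/C(=C\c1ccccc1)Oc1ccccc1OCCCNC(C)(C)C` at 1.5 mg/kg on these numbers. Compound 2 `CC(=O)/C(=C\c1ccccc1)Oc1ccc(OCC(C)N(C)C)cc1` gives 3 mg/kg and is higher than compound 1 by more than the scatter.

Compound 4 `CC(=O)/C(=C\c1ccccc1)Oc1ccccc1OCCCN(C)C` has the same atoms as compound 1, joined differently: 2-(dimethylamino)ethyl in place of 1-(dimethylamino)ethyl on a saturated chain carbon bound to an oxygen on an aromatic ring (read one bond further out, 3-(dimethylamino)propoxy in place of 2-(dimethylamino)propoxy).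

Among the measured compounds shown here, no measured pair isolates this change. The nearest evidence is a 1.7-fold higher number from compound 1 to compound 3 (0.22 log units; within the scatter) and this step also brings in the tert-butyl group, so it is only an indirect guide. For the measured compounds named here, its size stayed within the scatter, and no larger step is foreseen here.

The expected step in this assay is a 1.3-fold higher number from compound 1 to compound 4 (0.12 log units; within the scatter) and is estimated to stay within the scatter, with no firm direction.

For compound 4 the estimated value is 1.2 mg/kg with an expected range from 0.5 mg/kg to 3 mg/kg as the working bracket.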

Compound 4, dose for half-maximal effect: 0.37 mg/kg
The estimate for compound 4 lay 3.2-fold (0.51 log units) above the measured number; the measured number lies below the stated range.
By their numbers in this assay, from the lowest: compound 4; then compounds 1, 3 and 2 (each within the scatter of the next, the first and the last beyond it).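

In this assay, moving the dimethylamino group along the chain, from 2-(dimethylamino)propoxy to 3-(dimethylamino)propoxy with the atoms unchanged, gives a 2.4-fold lower number from compound 1 to compound 4 (0.39 log units; beyond the scatter), so the arrangement of this side chain matters even without a change in composition. On the 3-propoxy chain, the amine also matters: the step is a 4.1-fold lower number from compound 3 to compound 4 (0.61 log units; beyond the scatter), which the earlier comparison of compound 1 with compound 3 could not show because it changed the chain and the amine together. No measurement shown explains either step.

The compounds shown leave open whether diethylamino or a primary amine on the same chain would follow the dimethylamino or the (tert-butyl)amino result. They also leave open how a longer chain, such as 4-(dimethylamino)butoxy, would compare with compound 4.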